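The source may report more compounds than this note shows. Statements on the series, on what has been measured and on what is new or still open speak of the compounds shown alone.

The measured compounds, all tested in a functional assay on ACHN cells (Homo sapiens) for inhibition, read by sulforhodamine B assay, with a stated time of 48 h; on this read-out higher numbers stand for weaker inhibition of growth and lower numbers for stronger inhibition of growth:

Compound 1 `O=C(Nc1cccc(-n2cc(-c3ccncc3)c(-c3ccc(Cl)c(O)c3)n2)c1)Nc1ccc(Cl)c(Cl)c1` gives > 32500 nM, which is a limit of the assay and not a number.
Compound 2 `COc1cc(-c2nn(-c3cccc(NC(=O)c4cccc(C(F)(F)F)c4)c3)cc2-c2ccncc2)ccc1Cl` gives > 50000 nM, again a limit rather than a number.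
Compound 3 `O=C(Nc1cccc(-n2cc(-c3ccncc3)c(-c3ccc(Cl)c(O)c3)n2)c1)Nc1cc(C(F)(F)F)cc(C(F)(F)F)c1` gives 5270 nM.

Compound 1 therefore stands at a limit: the only firm statement is the limit of > 32500 nM in this assay, at which 1 of the 3 values shown sits. Compound 2 sits at another limit, (the limit of > 50000 nM in this assay, at which 1 of the 3 values shown sits), so among these three only compound 3 has a measured number in this assay. Within the data shown here, no two measured compounds differ in a single place, so no measured step is available to lean on.

Compound 4 `O=C(Nc1cccc(-n2cc(-c3ccncc3)c(-c3ccc(Cl)c(O)c3)n2)c1)Nc1ccc(Cl)c(C(F)(F)F)c1` has not yet been measured. It differs from compound 1 in one place: trifluoromethyl in place of chloro on an aromatic carbon. Compound 3 carries two trifluoromethyl groups on the corresponding ring and gives 5270 nM, a number well inside the range of the assay. Compound 1, by contrast, is known only by the limit already named. On that basis a modest gain in growth inhibition is expected, and the step from compound 1 to compound 4 is estimated as an at least 2.1-fold lower number from compound 1 to compound 4 (0.33 log units; beyond the scatter). For compound 4 the expected value in this assay is 15000 nM, with a range from 4000 nM to 50000 nM.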

Compound 4, concentration for total growth inhibition: > 32500 nM
Compound 4: a limit, no number (the forecaster's own chance of this, stated with the estimate: 40%); middle value at least 2.1-fold (0.33 log units) away from the limit.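

Compound 4, like compound 1, gives only a limit and not a number in this assay, so the change from chloro to trifluoromethyl between these two compounds cannot be read: the limit of > 32500 nM in this assay, at which 2 of the 4 values shown sit. The compounds shown leave open what number either compound would give, and whether this change alters growth inhibition at all.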